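Adding trifluoromethyl to a compound at the assay limit

The compounds below may be only part of what the source reports. "The series", "measured", "known", "first", "only" and "open" are said of these compounds alone.

In a functional assay on NCI-H23 cells (Homo sapiens) for antiproliferative activity, read by MTT assay, with a stated time of 72 h (a lower number here means a stronger inhibitor, a higher number a weaker inhibitor), compound 3 `C=CC(=O)Nc1cc(Nc2nccc(NC(=O)c3ccccc3)n2)c(OC)cc1N(C)CCN(C)C` gives > 16000 nM, which is a limit of the assay and not a number. Compound 3 thus stands at the limit of > 16000 nM in this assay, at which 1 of the 3 values shown sits, so its true potency is not known.

The change leading to compound 4 `C=CC(=O)Nc1cc(Nc2nccc(NC(=O)c3ccc(C(F)(F)F)cc3)n2)c(OC)cc1N(C)CCN(C)C` is trifluoromethyl in place of hydrogen on an aromatic carbon, turning phenyl into 4-(trifluoromethyl)phenyl.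

Within the data shown here, no measured step makes this exact change. The nearest evidence comes from compound 2 `C=CC(=O)Nc1cc(Nc2nccc(NC(=O)c3cccc(OC)c3)n2)c(OC)cc1N(C)CCN(C)C`, which gives 11800 nM in this assay. Replacing its methoxy with hydrogen gives an at least 1.3-fold higher number from compound 2 to compound 3 (0.13 log units; that floor lies within the scatter), so this step offers only weak support for any effect of substitution on this ring. Compound 1 `C=CC(=O)Nc1cc(Nc2nccc(NC(=O)c3ccc(C(F)(F)F)cc3)n2)c(OC)cc1N1CCN(C)CC1` also bears 4-(trifluoromethyl)phenyl but differs elsewhere, and it gives 9200 nM.

On this basis, a small move toward a lower number is expected, with the estimate being an at least 1.7-fold lower number from compound 3 to compound 4 (0.24 log units; that floor lies within the scatter). The expected value for compound 4 is 9000 nM, with an estimated range from 3500 nM to 16000 nM.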

Compound 4, half-maximal inhibitory concentration: 7980 nM
Compound 4: the middle estimate sits 1.1-fold (0.05 log units) above what was measured; low and high end bracket the measured number.
By their numbers in this assay, from the lowest: compounds 4, 1 and 2 (each within the scatter of the next). At a limit, above all of these: compound 3.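

Compound 3 is held at a limit of the assay and not a number: the limit of > 16000 nM in this assay, at which 1 of the 4 values shown sits. Trifluoromethyl in place of hydrogen, para to a large group, gives a measurable value in this assay, with an at least 2.0-fold lower number from compound 3 to compound 4 (0.30 log units; that floor lies within the scatter), but this is only a floor, so the true size of the change remains unknown. Against 3-methoxyphenyl, 4-(trifluoromethyl)phenyl gives a 1.5-fold lower number from compound 2 to compound 4 (0.17 log units; within the scatter), and (2-(dimethylamino)ethyl)(methyl)amino in place of 4-methylpiperazin-1-yl gives a 1.2-fold lower number from compound 1 to compound 4 (0.06 log units; within the scatter), so neither change separates these compounds.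

On these data alone, it remains open whether a single fluorine or chlorine atom or a nitrile at this place would give a value like that of compound 4. Nor do these compounds show what an amine or a carboxylic acid there would do.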